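This account rests on a few compounds, and the source may have more. Where it says the series, first, only, none or still open, it means among the compounds named here.

Within the data shown here, in a functional assay with Rattus norvegicus as the target (a lower number here means a stronger inhibitor, a higher number a weaker inhibitor), compound 1 `Cc1ccc2[nH]c(=O)c(=O)oc2c1` gives 32000 nM, and compound 2 `N#Cc1ccc2[nH]c(=O)c(=O)oc2c1` gives 15000 nM, the lower of the two numbers measured so far. Compound 3 `O=C(O)c1ccc2[nH]c(=O)c(=O)oc2c1` keeps the shared core and differs from compound 2 in one place: carboxy in place of cyano on an aromatic carbon. In words, carboxy stands in place of cyano on an aromatic carbon. Among the measured compounds shown here, only one measured step bears on this change, a 2.1-fold lower number from compound 1 to compound 2 (0.33 log units; beyond the scatter), which is modest and also concerns a group on an aromatic carbon. For the measured compounds named here, no measured compound carries a carboxy group, so the data give no firm direction. No step beyond the scatter is therefore expected in this assay, with only a slight lean towards a higher number. The estimate amounts to an expected 1.3-fold higher number from compound 2 to compound 3 (0.12 log units; within the scatter). For compound 3 the expected value is 20000 nM, with an estimated range from 6000 nM to 70000 nM.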

Compound 3, half-maximal inhibitory concentration: 16000 nM
Compound 3: middle estimate off by 1.3-fold (0.10 log units), on the high side; low and high end bracket the measured number.
By their numbers in this assay, from the lowest: compounds 2, 3 and 1 (each within the scatter of the next, the first and the last beyond it).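

In this assay, carboxy in place of cyano on this aromatic carbon gives a 1.1-fold higher number from compound 2 to compound 3 (0.03 log units; within the scatter), so this position accepts the entering group, with its hydrogen-bond donor, without a step beyond the scatter. Against methyl, carboxy gives a 2.0-fold lower number from compound 1 to compound 3 (0.30 log units; within the scatter), which stays within the scatter, while cyano gives a 2.1-fold lower number from compound 1 to compound 2 (0.33 log units; beyond the scatter), which lies just beyond it; cyano and carboxy cannot be told apart at this position. Nothing measured here offers an explanation for this result.

On these data alone, it remains open whether an amine, an amide or a methyl ester on this aromatic carbon would fall in the same range, or whether any group here would bring a much larger step. As far as these compounds go, the effect of changes elsewhere on the shared core also remains open.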